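Methyl on the chain carbon: compound 2 to compound 3

The compounds below may be only part of what the source reports. "The series", "measured", "known", "first", "only" and "open" are said of these compounds alone.

Compound 2 `N=C(S)CCn1ncccc1=O` carries the shared core with hydrogen on the aromatic carbon where compound 1 `N=C(S)CCn1nc(-c2cccs2)ccc1=O` carries thiophen-2-yl. In a functional assay on the whole organism (stomach) for inhibition, with Rattus norvegicus as the target, at a dose of 100 mg/kg by the intraduodenal route (a lower number here means less inhibition, a higher number more inhibition at the dose given (going by the name of the read-out)), compound 1 gives 50.2% and compound 2 gives 28.8%; the change is a number 21.4 percentage points lower from compound 1 to compound 2 (beyond the scatter). For the measured compounds named here, compound 2 thus stands lowest of the two numbers measured so far, its only neighbour being compound 1, which sits beyond the scatter above it.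

Compound 3 `CC(CC(=N)S)n1ncccc1=O` differs from compound 2 by methyl in place of hydrogen on a saturated chain carbon bound to an aromatic nitrogen and a saturated chain carbon. Going by the values given here, no measured step bears on this change: the only measured step concerns hydrogen in place of thiophen-2-yl on an aromatic carbon, a different place, and says nothing about a methyl entering on a saturated chain carbon bound to an aromatic nitrogen. With nothing to ground a shift in either direction, no step beyond the scatter is expected in this assay, so the estimated step of a number 1.2 percentage points higher from compound 2 to compound 3 (within the scatter) is taken as close to nil. Compound 3 is accordingly estimated at 30%, with a range from 12% to 50%.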

Compound 3, a percentage reported as inhibition, in the whole organism at one dose (the size of the read-out at that dose, not a potency): 38.8%
Estimate against measurement, compound 3: 8.8 percentage points below; the range from low to high includes it.
By their numbers in this assay, from the lowest: compounds 2 and 3 (each within the scatter of the next); then compound 1.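

In this assay, for the compounds shown here, methyl in place of hydrogen on a saturated chain carbon bound to an aromatic nitrogen and a saturated chain carbon gives a number 10 percentage points higher from compound 2 to compound 3 (within the scatter) and so stays inside the usual variation, which makes this the first reading at this chain carbon and shows that, on this single pair, the position takes a methyl without a step beyond the scatter. The earlier step, a number 21.4 percentage points lower from compound 1 to compound 2 (beyond the scatter) in the same read-out, concerned thiophen-2-yl on an aromatic carbon, and unlike the present step it separated its two compounds beyond the scatter, so among the compounds shown only the aromatic carbon has yet given a clear difference. No measurement at hand accounts for the size of the methyl step, in either direction.

A single small group cannot show whether this chain carbon is generally indifferent to substitution, and an ethyl, a longer chain, a hydroxyl or an amine in the same place would test that directly. Going by these compounds, it also remains open whether methyl on the chain carbon and thiophen-2-yl on the aromatic carbon would act independently when both are present on the shared core.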